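Halogen Swap on the Aryl Arm: Compound 2 to Compound 4

The source may hold more compounds than are shown below. What is called first, only, known or untested is meant among the compounds shown, and "the series" means these compounds.

Measured compounds:
- Compound 1, `COc1ccccc1/C=c1\c(=O)[nH]/c(=C/c2ccccc2Cl)c(=O)n1C`: "not determined" (no result reported)
- Compound 2, `C=CCn1c(=O)/c(=C\c2cccc(Br)c2)[nH]c(=O)/c1=C\c1ccccc1OC`: 5000 nM
- Compound 3, `C=CCn1c(=O)/c(=C\c2cc(OC)c(OC)c(OC)c2)[nH]c(=O)/c1=C\c1cccc(Br)c1`: "not active" (no number reported)

Three analogues sharing one core were tested in a functional assay on MOLT-4 cells (Homo sapiens) for cytotoxicity, read by CCK-8 assay, with a stated time of 72 h; a lower number here means a stronger inhibitor, a higher number a weaker inhibitor. Among the measured compounds shown here, compound 2 is the only one with a number: in this assay compound 2 gives 5000 nM. Compound 1 has no result in this assay, and compound 3 is reported as inactive there, so compound 2 stands alone as the single measured point rather than as the best or worst of a series.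

The next compound, compound 4, `C=CCn1c(=O)/c(=C\c2cccc(Cl)c2Cl)[nH]c(=O)/c1=C\c1ccccc1OC`, changes one arm: 2,3-dichlorophenyl in place of 3-bromophenyl on a double-bonded chain carbon bound to an aromatic carbon. For the measured compounds named here, nothing measured here connects a bromophenyl to a dichlorophenyl, so there is no step to lean on. With only compound 2 as an anchor, the step of no change at the digits printed from compound 2 to compound 4 (within the scatter) is expected to stay within the usual scatter, in no clear direction. Compound 4 is therefore estimated at 5000 nM, with a range from 1500 nM to 20000 nM, and a real chance that only a limit is reported, as for compound 3.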

Compound 4, half-maximal inhibitory concentration: 1200 nM
Beside the measured number, compound 4's estimate is 4.2-fold (0.62 log units) above it; measured number below the stated range.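

In this assay the swap to 2,3-dichlorophenyl gives a 4.2-fold lower number from compound 2 to compound 4 (0.62 log units; beyond the scatter) and so counts as a modest gain in potency. Among the compounds shown here, this is the first sign that the aryl group on this double-bonded chain carbon can change the reading beyond the scatter, with the rest of the molecule kept the same. Nothing available explains why the number falls at this position.

The swap changes both the kind of halogen and the number of halogens, so the compounds shown do not separate the loss of bromine from the gain of two chlorines. A phenyl ring with a single chlorine would help to pull these apart, and one carrying an amine or a carboxylic acid would test a very different kind of group on this arm.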